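A Sulfonate Ester Replaces the Amine on the Shared Core

The compounds below may be only part of what the source reports. "The series", "measured", "known", "first", "only" and "open" are said of these compounds alone.

Compound 1, `N[C@H]1CC[C@H](Nc2c(C(=O)NCc3ccc(F)cc3)nc(Br)c3cccnc23)CC1`: 4000 nM
Compound 2, `C[C@H](Nc1c(C(=O)NCc2ccc(F)cc2)nc(Br)c2cccnc12)c1ccccc1`: > 20000 nM
Compound 3, `O=C(NCc1ccc(F)cc1)c1nc(Br)c2cccnc2c1N1CCNCC1`: > 10000 nM

All three were tested in a functional assay on HCT-116 cells (Homo sapiens) for cytotoxicity, read by MTT assay, with a stated time of 72 h; on this read-out lower numbers stand for stronger inhibition and higher numbers for weaker inhibition. For the measured compounds named here, compound 1 gives 4000 nM, the only plain number of the set. For compound 2 the reported > 20000 nM is a limit of the assay, not a number. Compound 3 likewise stands at a limit, > 10000 nM, which is where (the limit of > 10000 nM in this assay, at which 1 of the 3 values shown sits); it is therefore not placed on the scale but only known to be weaker than that edge.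

Compound 4, `Cc1ccc(S(=O)(=O)Oc2c(C(=O)NCc3ccc(F)cc3)nc(Br)c3cccnc23)cc1`, differs from compound 3 in one place: ((4-methylphenyl)sulfonyl)oxy in place of piperazin-1-yl on an aromatic carbon. The measured steps all concern the same position of the shared core. an at least 2.5-fold higher number from compound 1 to compound 3 (0.39 log units; beyond the scatter) and an at least 5.0-fold higher number from compound 1 to compound 2 (0.69 log units; beyond the scatter) both weaken inhibition, while a step that the two limits leave unreadable from compound 2 to compound 3. Going by the values given here, none of them exchanges a basic amine for a sulfonate ester, so they show only that changes here are felt and that compound 3 already sits at the edge of measurement.

Compound 4 is therefore expected to stay weak, with a step that the limit leaves unreadable from compound 3 to compound 4 expected to lie within the scatter. The estimate for compound 4 is 15000 nM, ranging from 5000 nM to 50000 nM, and most likely the assay again reports only a limit.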

Compound 4, half-maximal inhibitory concentration: > 20000 nM
Compound 4: a limit, no number (the forecaster's own chance of this, stated with the estimate: 65%); middle value at least 1.3-fold (0.12 log units) away from the limit.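

Unlike the other three compounds, compound 4 carries oxygen rather than nitrogen on this aromatic carbon, and in this assay the one readable comparison is an at least 5.0-fold higher number from compound 1 to compound 4 (0.69 log units; beyond the scatter). Compound 4 gives a limit, not a number, and it stands at the same limit as compound 2: the limit of > 20000 nM in this assay, at which 2 of the 4 values shown sit. Each step linking compound 4 to compound 2 or compound 3 joins two limits and cannot be read, so a sulfonate ester at this position joins the (1-phenylethyl)amino and piperazin-1-yl groups in giving no plain number, leaving the (4-aminocyclohexyl)amino group of compound 1 as the only one shown that does.

The compounds shown leave open which part of the (4-aminocyclohexyl)amino group goes with that measurable value, for example whether a plain cyclohexylamino group without the second amine, or a short chain such as 2-aminoethylamino, would also give a number on this scale. They also leave open how far compound 2, compound 3 and compound 4 lie beyond their limits, and whether these three differ from one another at all.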